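Aryl variation on the shared core: cytotoxicity notes

This account rests on a few compounds, and the source may have more. Where it says the series, first, only, none or still open, it means among the compounds named here.

Compound 1 `COc1ccc(-c2nc(/C=C/c3cc4ccccc4nc3OC)no2)cc1` gives > 220000 nM.
Compound 2 `COc1nc2ccccc2cc1/C=C/c1noc(-c2ccc(Br)cc2)n1` gives > 195000 nM.
Compound 3 `COc1nc2ccccc2cc1/C=C/c1noc(-c2ccc(F)cc2)n1` gives > 230000 nM.

In an ADME assay on HepG2 cells (Homo sapiens) for cytotoxicity, read by sulforhodamine B assay, with a stated time of 48 h (on this read-out lower numbers stand for higher toxicity in this test and higher numbers for lower toxicity in this test), every value shown is a limit of the assay and not a number. Compound 3 stands at the limit of > 230000 nM in this assay, at which 1 of the 3 values shown sits. Compound 1 stands at the limit of > 220000 nM in this assay, at which 1 of the 3 values shown sits. Compound 2 stands at the limit of > 195000 nM in this assay, at which 1 of the 3 values shown sits. Because of this the steps among the measured compounds cannot be read: a step that the two limits leave unreadable from compound 1 to compound 2, a step that the two limits leave unreadable from compound 1 to compound 3 and a step that the two limits leave unreadable from compound 2 to compound 3.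

Compound 4 `COc1cccc(-c2nc(/C=C/c3cc4ccccc4nc3OC)no2)c1` differs from compound 3 by 3-methoxyphenyl in place of 4-fluorophenyl on an aromatic carbon. The measured steps that touch the same aromatic carbon, bromo or fluoro or methoxy in place of one another, all end at limits, so no direction or size can be taken from them for this assay; the expectation is that compound 4 again gives no readable value, with no step beyond the scatter, an at least 1.0-fold lower number from compound 3 to compound 4 (0.01 log units; that floor lies within the scatter). Compound 4 is therefore estimated at 220000 nM, in a range from 100000 nM to 350000 nM, most likely reported as a limit.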

Compound 4, half-maximal cytotoxic concentration: > 220000 nM
Compound 4: only a limit was reported; the forecaster's own chance of this, stated with the estimate: 80%; the middle value sits exactly at the limit.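

In this assay compound 4 gives > 220000 nM, a limit of the assay and not a number. Among the compounds shown here, no step from compound 1, compound 2 or compound 3 to compound 4 can be read. The compounds shown leave open whether any of these aryl groups on the shared core changes the result in this assay.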